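Replacing a Methylpiperazine with Methylamino on the Shared Core

The source may hold more compounds than are shown below. What is called first, only, known or untested is meant among the compounds shown, and "the series" means these compounds.

Of the compounds shown here, three have been measured in a functional assay on SW480 cells (Homo sapiens) for inhibition, read by luminescence and resazurin assay, with a stated time of 3 days; on this read-out higher numbers stand for weaker inhibition and lower numbers for stronger inhibition. Compound 1 `CCCNc1nc(NCc2ccc(C(=O)Nc3ccc(F)cc3)cc2)c2cc(C)ccc2n1` gives 1300 nM in this assay. Compound 3 `Cc1ccc2nc(N(C)C)nc(NCc3ccc(C(=O)NCc4ccc(F)cc4)cc3)c2c1` gives 1100 nM. Compound 2 `Cc1ccc2nc(N3CCNC(C)C3)nc(NCc3ccc(C(=O)NC4CCN(Cc5ccc(F)cc5)CC4)cc3)c2c1` gives 1000 nM; its number sits at the low end of the three, yet the gaps to compound 3 and to compound 1 both stay inside the usual scatter, so the three cannot be told apart on these numbers.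

Compound 4 `CNc1nc(NCc2ccc(C(=O)NC3CCN(Cc4ccc(F)cc4)CC3)cc2)c2cc(C)ccc2n1` is not yet measured. It differs from compound 2 in one place: methylamino in place of 3-methylpiperazin-1-yl on an aromatic carbon. Since compound 1 carries propylamino and compound 3 dimethylamino at that same place and neither stands apart from compound 2, no step beyond the scatter is expected in this assay. The expected step is a 1.3-fold higher number from compound 2 to compound 4 (0.11 log units; within the scatter), essentially none beyond the scatter. Compound 4 is therefore expected to give about 1300 nM in this assay, with a range from 600 nM to 3000 nM.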

Compound 4, half-maximal inhibitory concentration: 1300 nM
For compound 4 middle estimate and measured number coincide at the digits printed; the measured number falls inside the stated range.
By their numbers in this assay, from the lowest: compounds 2, 3, 1 and 4 (each within the scatter of the next).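

Among these compounds, exchanging 3-methylpiperazin-1-yl for methylamino on the aromatic carbon between two ring nitrogen atoms gives a 1.3-fold higher number from compound 2 to compound 4 (0.11 log units; within the scatter) in this assay and is the first comparison here in which only this group differs. The group can thus go from 7 heavy atoms with a six-membered ring to 2 heavy atoms with no ring without a change that this read-out can distinguish from scatter. Nothing shown accounts for this flat result.

On these data alone, compound 1 and compound 3 differ from compound 4 in more than one place, so it remains open whether the side chain on the other side of the core affects how this position responds. Also open, as far as these compounds go, is how a morpholine ring, a carboxylic acid or a plain hydrogen at this place would read.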